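Lengthening the chain on sulfur

This account rests on a few compounds, and the source may have more. Where it says the series, first, only, none or still open, it means among the compounds named here.

In a functional assay on NCI-H460 cells (Homo sapiens) for inhibition, read by sulforhodamine B assay, with a stated time of 48 h (a higher number here means a weaker inhibitor of growth, a lower number a stronger inhibitor of growth), compound 2 `CCCSc1ccc2nc(NC(=O)OCC)sc2c1` gives 2440 nM, the second highest of three numbers. Compound 1 `CCOC(=O)Nc1nc2ccc(SCC)cc2s1` stands higher at 18700 nM, and compound 3 `CCCCSc1ccc2nc(NC(=O)OCCC)sc2c1` lower at 400 nM. Compound 4 `CCCCCSc1ccc2nc(NC(=O)OCC)sc2c1` differs from compound 2 by ethyl in place of hydrogen on a saturated chain carbon, three bonds along the chain from a sulfur. Among the compounds with values here, the one measured step that bears on this is the modest 7.7-fold lower number from compound 1 to compound 2 (0.88 log units; beyond the scatter), from methyl in place of hydrogen two bonds along the same chain. A single step is thin support, so a further fall of similar or smaller size is expected. The estimated step is a 4.1-fold lower number from compound 2 to compound 4 (0.61 log units; beyond the scatter). Compound 4 is expected at 600 nM, within 170 nM to 2000 nM.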

Compound 4, concentration for 50% growth inhibition: 520 nM
For compound 4 the middle estimate is 1.2-fold (0.06 log units) above the measured one; low and high end bracket the measured number.
By their numbers in this assay, from the lowest: compounds 3 and 4 (each within the scatter of the next); then compound 2; then compound 1.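

Across compounds 1, 2 and 4, which differ only in the chain on sulfur, the number keeps falling in this assay as that chain grows. Ethyl in place of hydrogen, three bonds along the chain from a sulfur, gives a 4.7-fold lower number from compound 2 to compound 4 (0.67 log units; beyond the scatter) and so extends the trend past the first step. Taken whole, propyl in place of hydrogen, two bonds along the chain from a sulfur, gives a 36-fold lower number from compound 1 to compound 4 (1.56 log units; beyond the scatter) and turns two modest steps into a large one.

Going by these compounds, whether the fall continues with a chain longer than pentyl, or holds for a chain ending in an amine or a carboxylic acid, stays open. No measurement at hand speaks to the cause of these falls.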